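The source may hold more compounds than are shown below. What is called first, only, known or untested is meant among the compounds shown, and "the series" means these compounds.

Measured so far:
compound 1 `COc1nc(C)c(Nc2nc(Cl)cn([C@H](COC(=O)c3ccccn3)C3CC3)c2=O)cc1C`: 67 nM
compound 2 `COc1nc(C)c(Nc2nc(Cl)cn([C@H](COC(=O)c3cccnc3)C3CC3)c2=O)cc1C`: 5.2 nM
compound 3 `COc1nc(C)c(Nc2nc(Cl)cn([C@H](COC(=O)Nc3cccc(C#N)c3)C3CC3)c2=O)cc1C`: 1.3 nM

All three share one core and differ only in the group on the carbonyl carbon. In an assay on frontal cortex for displacement of a labelled ligand from corticotropin-releasing factor receptor 1 (Rattus norvegicus), with a stated time of 2 h (a lower number here means a stronger inhibitor, a higher number a weaker inhibitor), compound 2 holds the middle place of the three numbers: a 4.0-fold lower number from compound 2 to compound 3 (0.60 log units; beyond the scatter) and a 13-fold lower number from compound 1 to compound 2 (1.11 log units; beyond the scatter), both beyond the scatter.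

Compound 4 `CCNC(=O)OC[C@H](C1CC1)n1cc(Cl)nc(Nc2cc(C)c(OC)nc2C)c1=O` differs from compound 2 by ethylamino in place of pyridin-3-yl on a carbonyl carbon. The two steps that bear on this position are a 13-fold lower number from compound 1 to compound 2 (1.11 log units; beyond the scatter) and a 4.0-fold lower number from compound 2 to compound 3 (0.60 log units; beyond the scatter); both show that this carbonyl substituent moves the number strongly. Neither step, however, involves an alkylamino group, so the direction for compound 4 is not settled by the data, and the expected step of a 1.2-fold higher number from compound 2 to compound 4 (0.06 log units; within the scatter) is taken as no change beyond the scatter. Compound 4 is therefore estimated at 6 nM, with a range from 1.5 nM to 25 nM.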

Compound 4, half-maximal inhibitory concentration: 14 nM
Compound 4: the middle estimate sits 2.3-fold (0.37 log units) below what was measured, and the stated range covers the measured number.
By their numbers in this assay, from the lowest: compound 3; then compound 2; then compound 4; then compound 1.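

In this assay an alkylamino group on the carbonyl carbon now has a place in the series: ethylamino beats pyridin-2-yl with a 4.8-fold lower number from compound 1 to compound 4 (0.68 log units; beyond the scatter) but falls short of pyridin-3-yl with a 2.7-fold higher number from compound 2 to compound 4 (0.43 log units; beyond the scatter). On the amide-type nitrogen itself, the choice of substituent matters, with an 11-fold higher number from compound 3 to compound 4 (1.03 log units; beyond the scatter) when ethyl replaces 3-cyanophenyl. No measurement shown accounts for these differences.

Open, from the compounds shown here alone, is whether a longer chain such as butyl on that nitrogen moves the number toward that of compound 3. Also open, going by these compounds, is whether phenylamino, without the nitrile, matches compound 3.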